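This account rests on a few compounds, and the source may have more. Where it says the series, first, only, none or still open, it means among the compounds named here.

Working notes on the series. Compound 3 `CCCCCCCCCCCCCCCCCCNC(=O)[C@@H](NC(=O)c1ccco1)[C@@H](C)O` gives 21400 nM in a functional assay on MCF7 cells (Homo sapiens) for cytotoxicity, read by MTT assay, with a stated time of 48 h (on this read-out lower numbers stand for stronger inhibition and higher numbers for weaker inhibition), the lowest of the three numbers in hand. Compound 2 `CCCCCCCCCCCCCCCCCCNC(=O)[C@@H](NC(=O)c1ccccc1)[C@@H](C)O` gives 31800 nM in this assay, and the step of a 1.5-fold lower number from compound 2 to compound 3 (0.17 log units; within the scatter) sits within the scatter. Compound 1 `CCCCCCCCNC(=O)[C@@H](NC(=O)c1nccc2ccccc12)[C@@H](C)O` gives 63200 nM in this assay, a number beyond the scatter from compound 3. Compound 4 `CCCCCCCCCCCCCCCCCCNC(=O)[C@@H](NC(=O)c1nccc2ccccc12)[C@@H](C)O` differs from compound 3 by isoquinolin-1-yl in place of furan-2-yl on a carbonyl carbon. Going by the values given here, no measured step covers this change directly; compound 1 carries the same isoquinolin-1-yl group but differs from compound 4 elsewhere, so its value is only a rough hint. A modest step toward a higher number is expected, a 1.6-fold higher number from compound 3 to compound 4 (0.21 log units; within the scatter). Compound 4 is expected to give 35000 nM in this assay, within 12000 nM to 100000 nM.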

Compound 4, half-maximal inhibitory concentration: 30800 nM
Beside the measured number, compound 4's estimate is 1.1-fold (0.06 log units) above it, within the range that was stated.
By their numbers in this assay, from the lowest: compounds 3, 4, 2 and 1 (each within the scatter of the next, the first and the last beyond it).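

In this assay the place on the carbonyl carbon takes isoquinolin-1-yl without a readable shift, with a 1.4-fold higher number from compound 3 to compound 4 (0.16 log units; within the scatter) and a 1.0-fold lower number from compound 2 to compound 4 (0.01 log units; within the scatter) leaving furan-2-yl, phenyl and isoquinolin-1-yl unresolved. Going by these compounds alone, with isoquinolin-1-yl held constant, the chain now gets its own reading, a 2.1-fold lower number from compound 1 to compound 4 (0.31 log units; beyond the scatter) and this is the only step here beyond the scatter. No measurement at hand gives a reason for either result. On these data alone, whether an amine or a carboxylic acid on the aromatic group, or a longer chain, would move the number stays open.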